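The source may hold more compounds than are shown below. What is called first, only, known or untested is meant among the compounds shown, and "the series" means these compounds.

Measured so far:
- compound 1, `C[Se]/C(=N\C(=O)c1cc2ccccc2s1)NC(=O)c1cc2ccccc2s1`: 490 nM
- compound 2, `CS/C(=N\C(=O)c1csc([N+](=O)[O-])c1)NC(=O)c1csc([N+](=O)[O-])c1`: 1550 nM

In an ADME assay on MCF-10A cells (Homo sapiens) for cytotoxicity, read by MTT assay, with a stated time of 72 h (a higher number here means a weaker inhibitor of growth, a lower number a stronger inhibitor of growth), compound 1 holds the lower of the two numbers; compound 2 stands higher by a gap beyond the scatter. Compound 3, `CS/C(=N\C(=O)c1cc2ccccc2s1)NC(=O)c1cc2ccccc2s1`, differs from compound 1 by a group of 2 heavy atoms (1 carbon, 1 sulfur; no ring) in place of a group of 2 heavy atoms (1 carbon, 1 selenium; no ring), on a carbon with a double bond to nitrogen. Among the measured compounds shown here, no measured pair shows this exchange. A moderate weakening of growth inhibition is expected, a step of a 2.0-fold higher number from compound 1 to compound 3 (0.31 log units; beyond the scatter) somewhat beyond the scatter. Compound 3 is estimated at 1000 nM, range 400 nM to 2600 nM.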

Compound 3, concentration for 50% growth inhibition: 20 nM
Estimate against measurement, compound 3: 50-fold (1.70 log units) above; the measured number lies below the stated range.
By their numbers in this assay, from the lowest: compound 3; then compound 1; then compound 2.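

In this assay methylsulfanyl in place of the group of carbon and selenium, on a carbon with a double bond to nitrogen, gives a 25-fold lower number from compound 1 to compound 3 (1.39 log units; beyond the scatter) and this counts as a large step. With the core of compound 1 held constant, the exchange of selenium for sulfur alone moves growth inhibition well beyond the scatter, so this position is sensitive to a change of a single atom. No measurement at hand accounts for the step.

On these data alone, whether the same exchange gives a step of similar size on the core of compound 2 stays open. As far as these compounds go, the response of this position to an amine or to a longer chain such as ethylsulfanyl also stays open.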